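Cytotoxicity of Two Triazole-Free Neighbours: One Aryl Swap

The source may hold more compounds than are shown below. What is called first, only, known or untested is meant among the compounds shown, and "the series" means these compounds.

Measured so far:
Compound 1 `Cc1ccc(-n2nc(-c3ccc(C(F)(F)F)cc3O)nc2-c2ccccc2O)cc1`: 102%
Compound 2 `Oc1cc(C(F)(F)F)ccc1-c1nc(-c2ccccc2O)n(-c2ccc(C(F)(F)F)cc2)n1`: 102%

Both compounds were tested in a functional assay on PC-12 cells (Rattus norvegicus) for cytotoxicity, read by MTT assay, with stated times of 2 h and 24 h, tested at 10 uM; a higher number here means a stronger effect of the compound at the concentration tested, a lower number a weaker effect. Compound 1 stands level with compound 2 at the digits shown; the only measured step, no change at the digits printed from compound 1 to compound 2 (within the scatter), lies within the scatter, so the two numbers cannot be ordered.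

Compound 3 `COc1ccccc1-n1nc(-c2ccc(C(F)(F)F)cc2O)nc1-c1ccccc1O` has not yet been measured. It differs from compound 1 by 2-methoxyphenyl in place of 4-methylphenyl on an aromatic nitrogen.

Within the data shown here, the one measured step bears directly on this change, since it also altered the aryl group carried on the aromatic nitrogen and produced no change. Among the measured compounds shown here, with only that step as a guide, the expected step of a number 2 percentage points lower from compound 1 to compound 3 (within the scatter) is none beyond the scatter. Compound 3 is therefore estimated at 100%, with a range from 85% to 110%.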

Compound 3, a percentage reported as activity, at one concentration (the size of the read-out at that concentration, not a potency): 96.2%
Compound 3: middle estimate off by 3.8 percentage points, on the high side; low and high end bracket the measured number.
By their numbers in this assay, from the lowest: compounds 3, 1 and 2 (each within the scatter of the next).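

In this assay, exchanging 4-methylphenyl for 2-methoxyphenyl on the aromatic nitrogen gives a number 5.8 percentage points lower from compound 1 to compound 3 (within the scatter), and exchanging 4-(trifluoromethyl)phenyl for it gives a number 5.8 percentage points lower from compound 2 to compound 3 (within the scatter). The earlier step only swapped one group at the 4 position of the phenyl ring for another, whereas this change puts a group at the 2 position and adds an oxygen, and the read-out still does not separate the three compounds. No supporting measurement is available that would explain this outcome.

Going by these compounds, all three groups at this position are substituted phenyl rings, so it remains open whether a saturated cyclohexyl ring, or a phenyl ring carrying an amine or a carboxylic acid, would read the same. A single concentration also leaves potency open.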